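The compounds below may be only part of what the source reports. "The series", "measured", "known", "first", "only" and "open" are said of these compounds alone.

Of the compounds shown here, three that share one core have been tested in a functional assay on KOPN-8 cells (Homo sapiens) for antiproliferative activity, with a stated time of 72 h; a lower number here means that less compound is needed, a higher number that more compound is needed for the effect. Compound 1 `COc1ccc(-c2cc(=O)c3c(OC)cc(OC)cc3n2S(=O)(=O)c2cc(F)c(F)c(F)c2)cc1` gives only a limit of the assay, > 65500 nM. Compound 2 `COc1ccc(-c2cc(=O)c3c(OC)cc(OC)cc3n2S(=O)(=O)c2cc(Cl)cc(Cl)c2O)cc1` likewise returns a limit, > 37900 nM. Compound 3 `COc1ccc(-c2cc(=O)c3c(OC)cc(OC)cc3n2S(=O)(=O)c2ccc(Br)cc2)cc1` also stays at a limit, > 86200 nM. With all three values at limits, the steps between them cannot be read: a step that the two limits leave unreadable from compound 1 to compound 2, a step that the two limits leave unreadable from compound 1 to compound 3 and a step that the two limits leave unreadable from compound 2 to compound 3. Compound 3 thus stands at the limit of > 86200 nM in this assay, at which 1 of the 3 values shown sits. The other two values shown are limits as well.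

Compound 4 `COc1ccc(-c2cc(=O)c3c(OC)cc(OC)cc3n2S(=O)(=O)c2ccc(Br)s2)cc1` differs from compound 3 in one place: 5-bromothiophen-2-yl in place of 4-bromophenyl on a sulfonyl sulfur. Among the compounds with values here, none of the measured steps bears on this change in a readable way, as every one of them is hidden behind a limit. Within the data shown here, the only guidance is that no compound in this set has reached a measurable value, so for compound 4 no step beyond the scatter is expected in an at least 1.0-fold lower number from compound 3 to compound 4 (0.03 log units; that floor lies within the scatter). Compound 4 is therefore estimated at 80000 nM, with a range from 20000 nM to 300000 nM.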

Compound 4, half-maximal effective concentration: > 48200 nM
Compound 4 gave a limit, no number; the forecaster's own chance of this, stated with the estimate: 85%; the middle value lies beyond the limit too.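

Compound 4 also returns only a limit in this assay, > 48200 nM, so its steps to compound 1, compound 2 and compound 3 cannot be read. The compounds shown leave open whether any group on the sulfonyl sulfur gives a measurable value in this assay.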